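Swapping a Chlorinated Benzyl for a Methylated One

The source may hold more compounds than are shown below. What is called first, only, known or untested is meant among the compounds shown, and "the series" means these compounds.

Compounds 1, 2 and 3 share one core and differ only in the group on a saturated chain carbon bound to an amine nitrogen in a ring. Compound 1 `CCCCCCCN1CCC(C(=O)Nc2cc(Cl)c(N)cc2OC)CC1` carries hexyl there, compound 2 `COc1cc(N)c(Cl)cc1NC(=O)C1CCN(Cc2ccc(Cl)cc2)CC1` carries 4-chlorophenyl, and compound 3 `COc1cc(N)c(Cl)cc1NC(=O)C1CCN(CC2CCCCCC2)CC1` carries cycloheptyl. In a functional assay on the whole organism for antagonist activity, with Mus musculus as the target (on this read-out lower numbers stand for an effect already at smaller amounts and higher numbers for an effect only at larger amounts of compound), compound 1 reaches only the limit > 10 mg/kg. Compound 3 also stops at the limit > 10 mg/kg. For the measured compounds named here, compound 2 gives 1.2 mg/kg, the only read number among the three, and it stands alone as the one compound with a measurable dose. The measured steps show an at least 8.3-fold lower number from compound 1 to compound 2 (0.92 log units; beyond the scatter) and an at least 8.3-fold higher number from compound 2 to compound 3 (0.92 log units; beyond the scatter), while a step that the two limits leave unreadable from compound 1 to compound 3; this follows from the limit of > 10 mg/kg in this assay, at which 2 of the 3 values shown sit.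

Compound 4 `COc1cc(N)c(Cl)cc1NC(=O)C1CCN(Cc2cccc(C)c2)CC1` keeps everything of compound 2 except (3-methylphenyl in place of 4-chlorophenyl on a saturated chain carbon bound to an amine nitrogen in a ring). The two readable steps both set an aromatic ring against a saturated group, and both favour the aromatic ring; neither exchanges one substituted benzyl for another, so they give no scale for this smaller change. Since the aromatic ring stays, the expectation is a number near that of compound 2, perhaps slightly higher, so for compound 4 the expected step is a 2.1-fold higher number from compound 2 to compound 4 (0.32 log units; beyond the scatter). The estimate for compound 4 is 2.5 mg/kg, within 0.8 mg/kg to 9 mg/kg.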

Compound 4, dose for half-maximal effect: 2.4 mg/kg
Beside the measured number, compound 4's estimate is 1.0-fold (0.02 log units) above it; low and high end bracket the measured number.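

In this assay, for the compounds shown here, the exchange of 4-chlorophenyl for 3-methylphenyl gives a 2.0-fold higher number from compound 2 to compound 4 (0.30 log units; within the scatter), so compound 2 and compound 4 cannot be told apart, and the first exchange between two substituted aromatic rings at this position leaves the dose within the usual scatter. The chlorine is therefore not needed for a readable dose here, and the contrast with the saturated groups also holds for this second aromatic ring, with an at least 4.1-fold lower number from compound 3 to compound 4 (0.61 log units; beyond the scatter) and an at least 4.1-fold lower number from compound 1 to compound 4 (0.61 log units; beyond the scatter). Both of these steps are only minimum sizes, and the true gaps cannot be read, because compound 1 and compound 3 each stop at a limit rather than a number: the limit of > 10 mg/kg in this assay, at which 2 of the 4 values shown sit.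

The exchange alters both the kind of substituent and its printed ring number, so the compounds shown cannot separate the two, and 3-chlorophenyl or 4-methylphenyl in the same place would be needed to do so. Going by these compounds, it also stays open whether the aromatic ring needs a substituent at all, which plain phenyl would test, and whether a ring containing nitrogen, such as pyridyl, would fit this position as well.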